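This account rests on a few compounds, and the source may have more. Where it says the series, first, only, none or still open, it means among the compounds named here.

Measured in a functional assay on HeLa cells (Homo sapiens) for cytotoxicity, read by MTT assay, with a stated time of 48 h; a lower number here means a stronger inhibitor, a higher number a weaker inhibitor:

Compound 1, `N#Cc1ccc(Cn2cc(COc3ccc4c(=O)ccoc4c3)nn2)cc1`, gives > 100000 nM, which is a limit of the assay (the limit of > 100000 nM in this assay, at which 1 of the 3 values shown sits).
Compound 2, `O=c1ccoc2cc(OCc3cn(Cc4ccc(Cl)cc4Cl)nn3)ccc12`, gives 80600 nM.
Compound 3, `O=c1ccoc2cc(OCc3cn(Cc4ccc(F)cc4)nn3)ccc12`, gives 12000 nM.

Compound 3 holds the lowest of the two numbers; the nearest is compound 2, with a 6.7-fold lower number from compound 2 to compound 3 (0.83 log units; beyond the scatter) beyond the scatter. Compound 4, `O=c1ccoc2cc(OCc3cn(Cc4cccc([N+](=O)[O-])c4)nn3)ccc12`, is not yet measured; the change is 3-nitrophenyl in place of 4-fluorophenyl on a saturated chain carbon bound to an aromatic nitrogen.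

Both known steps replace the aryl group on the same saturated chain carbon bound to an aromatic nitrogen: an at least 8.3-fold lower number from compound 1 to compound 3 (0.92 log units; beyond the scatter) and a 6.7-fold lower number from compound 2 to compound 3 (0.83 log units; beyond the scatter). Each exchange away from 4-fluorophenyl gave a higher number, so a modest rise beyond the scatter is expected for 3-nitrophenyl as well, with some chance that only a limit is reported.

Compound 4 is expected at 40000 nM, in the range 10000 nM to 150000 nM, corresponding to an expected 3.3-fold higher number from compound 3 to compound 4 (0.52 log units; beyond the scatter).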

Compound 4, half-maximal inhibitory concentration: 17300 nM
For compound 4 the middle estimate is 2.3-fold (0.36 log units) above the measured one; low and high end bracket the measured number.
By their numbers in this assay, from the lowest: compounds 3 and 4 (each within the scatter of the next); then compound 2. At a limit, above all of these: compound 1.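

In this assay the place on the saturated chain carbon bound to an aromatic nitrogen tolerates a second aryl group as well as 4-fluorophenyl, with a 1.4-fold higher number from compound 3 to compound 4 (0.16 log units; within the scatter) as the step, so the low end of the series no longer rests on one group. The change from 2,4-dichlorophenyl gives a 4.7-fold lower number from compound 2 to compound 4 (0.67 log units; beyond the scatter) and the change from 4-cyanophenyl gives an at least 5.7-fold lower number from compound 1 to compound 4 (0.76 log units; beyond the scatter). The second of these steps starts from a limit for compound 1: the limit of > 100000 nM in this assay, at which 1 of the 4 values shown sits.

Open, as far as these compounds go, is what an aminomethyl group or a carboxylic acid on the aryl group would give. Also open, from the compounds shown here alone, is the effect of a longer chain in place of the saturated chain carbon.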